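Freeing the phenol: compound 1 to compound 4

This account rests on a few compounds, and the source may have more. Where it says the series, first, only, none or still open, it means among the compounds named here.

Compound 1 `COc1ccc(-c2cc3c(OC)cc(OC)cc3n(C)c2=O)cc1` was tested in a functional assay on U-87MG ATCC cells for cytotoxicity against U-87 MG (Homo sapiens), read by colorimetric assay and MTT assay (a higher number here means a weaker inhibitor, a lower number a stronger inhibitor), where compound 1 gives 10000 nM. Its two companions vary only the chain on the aromatic nitrogen: compound 2 `COc1ccc(-c2cc3c(OC)cc(OC)cc3n(CCC#N)c2=O)cc1` gives 10000 nM and compound 3 `COc1ccc(-c2cc3c(OC)cc(OC)cc3n(CCC(=O)OCc3ccccc3)c2=O)cc1` gives 10000 nM. The three values stand level, and the steps confirm this: no change at the digits printed from compound 1 to compound 2 (within the scatter), no change at the digits printed from compound 1 to compound 3 (within the scatter) and no change at the digits printed from compound 2 to compound 3 (within the scatter) all lie within the scatter. Compound 1 therefore sits at the same level as compound 2 and compound 3, with no ordering among them.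

Compound 4 `COc1cc(OC)c2cc(-c3ccc(O)cc3)c(=O)n(C)c2c1` is the next member. Its change from compound 1 is hydrogen in place of methyl on an oxygen on an aromatic ring. Within the data shown here, none of the measured steps touches this part of the molecule; each of them alters the chain on the aromatic nitrogen and each was flat. Among the measured compounds shown here, the data thus give no measured step that bears directly on the change, and nothing in them suggests a move beyond the scatter. The expected step is no change at the digits printed from compound 1 to compound 4 (within the scatter). Compound 4 is estimated at 10000 nM, in a range from 5000 nM to 20000 nM.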

Compound 4, half-maximal inhibitory concentration: 10000 nM
Beside the measured number, compound 4's estimate shows no gap at the digits printed; the measured number falls inside the stated range.
By their numbers in this assay, from the lowest: compounds 1, 2, 3 and 4 (each within the scatter of the next).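

In this assay the change from 4-methoxyphenyl to 4-hydroxyphenyl gives no change at the digits printed from compound 1 to compound 4 (within the scatter) and is the first step shown that lies away from the chain on the aromatic nitrogen. A flat reading therefore holds at a second place in the molecule, as replacing methyl with hydrogen on this oxygen leaves compound 4 at 10000 nM and level with the other compounds. Nothing measured here offers an explanation for this flat step.

The compounds shown leave open whether an amine or a carboxylic acid in place of the hydroxy on this ring would move the value at all. They also leave open whether a longer chain on this oxygen, or a change to the methoxy groups on the shared core, would do so.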